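Compound 1 to compound 4: swapping ethyl for pyridin-2-yl

The compounds below may be only part of what the source reports. "The series", "measured", "known", "first", "only" and "open" are said of these compounds alone.

Measured so far:
Compound 1, `CCN1CCN(c2cccc3c2C[C@H](CN(C)[C@H]2CCCc4cccnc42)NC3)CC1`: 0%
Compound 2, `C[C@@H]1CN(c2cccc3c2C[C@H](CN(C)[C@H]2CCCc4cccnc42)NC3)C[C@H](C)N1C`: 24.6%
Compound 3, `CN(C[C@H]1Cc2c(cccc2N2C[C@H]3C[C@@H]2CN3)CN1)[C@H]1CCCc2cccnc21`: 100%

In an ADME assay on microsomes from liver (Homo sapiens) for metabolic stability, read by LC-MS, with a stated time of 10 min (on this read-out higher numbers stand for a more stable compound and lower numbers for a less stable compound), compound 1 gives 0%, the lowest of the three numbers. Compound 2 sits nearer, and compound 3 furthest, as the steps show: a number 24.6 percentage points higher from compound 1 to compound 2 (beyond the scatter), and a number 100 percentage points higher from compound 1 to compound 3 (beyond the scatter). Between the two higher compounds the step is a number 75.4 percentage points higher from compound 2 to compound 3 (beyond the scatter).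

Compound 4, `CN(C[C@H]1Cc2c(cccc2N2CCN(c3ccccn3)CC2)CN1)[C@H]1CCCc2cccnc21`, is not yet measured. It differs from compound 1 in one place: pyridin-2-yl in place of ethyl on an amine nitrogen in a ring. The group on the aromatic carbon stays a six-membered non-aromatic ring with 2 nitrogen; only what sits on the ring nitrogen changes.

For the measured compounds named here, no measured step alters that nitrogen alone. The steps from compound 1 both replace the whole ring group: one modest, a number 24.6 percentage points higher from compound 1 to compound 2 (beyond the scatter), one large, a number 100 percentage points higher from compound 1 to compound 3 (beyond the scatter). They show that compound 1 has room only upward in this assay and that changes in this region have moved the number beyond the scatter. The change to compound 4 is smaller in kind, so a modest rise is the expectation, though a result within the scatter cannot be ruled out.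

The estimate for compound 4 in this assay is 20%, within 0% to 55%, an expected step of a number 20 percentage points higher from compound 1 to compound 4 (beyond the scatter).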

Compound 4, percent of the compound remaining: 27.4%
Compound 4: middle estimate off by 7.4 percentage points, on the low side; low and high end bracket the measured number.
By their numbers in this assay, from the lowest: compound 1; then compounds 2 and 4 (each within the scatter of the next); then compound 3.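

In this assay, the change on the amine nitrogen alone gives a number 27.4 percentage points higher from compound 1 to compound 4 (beyond the scatter). For the compounds shown here, this shows that what sits on that ring nitrogen can by itself move the number beyond the scatter, with the six-membered non-aromatic ring with 2 nitrogen kept in place, something the earlier steps could not show since each replaced the whole group on the aromatic carbon. Nothing measured here speaks to the reason for this rise.

The compounds shown leave open whether the rise needs the ring nitrogen of pyridin-2-yl or would also come with phenyl, which has the same ring size without that nitrogen, and whether a longer alkyl chain such as propyl in place of ethyl would move the number at all. They also leave open what pyridin-2-yl would do on the free ring nitrogen of the group in compound 3, and so whether a change at this nitrogen still matters once the ring group itself has been replaced.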